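A few compounds are considered here, and "the series" means these few. Any claim that something is new, unique, unknown or untested is made for them only; others in the source may bear on it.

Series on the shared core of compound 1 `CCOC(=O)c1c(-c2cccc(OC(C)C)c2)[nH]c2cc(OC)ccc2c1=O`, varied at one substituent of the pendant aromatic ring, read in an ADME assay on HepG2 cells (Homo sapiens) for cytotoxicity, read by luminescence, with a stated time of 72 h; a higher number here means that more compound is needed for the effect, a lower number that less compound is needed. In this assay compound 1 gives only a limit, > 21500 nM. Compound 2 `CCOC(=O)c1c(-c2cccc(OCc3ccccc3)c2)[nH]c2cc(OC)ccc2c1=O` carries benzyl in place of isopropyl on an oxygen on an aromatic ring; in this assay compound 2 likewise gives only a limit, > 21500 nM. Compound 3 `CCOC(=O)c1c(-c2cccc(C(F)(F)F)c2)[nH]c2cc(OC)ccc2c1=O` carries trifluoromethyl in place of isopropoxy on an aromatic carbon; in this assay compound 3 also gives only a limit, > 21500 nM. The steps a step that the two limits leave unreadable from compound 1 to compound 2, a step that the two limits leave unreadable from compound 1 to compound 3 and a step that the two limits leave unreadable from compound 2 to compound 3 are all unreadable, since every value sits at the limit of > 21500 nM in this assay, at which 3 of the 3 values shown sit. Compound 4 `CCOC(=O)c1c(-c2cccc([N+](=O)[O-])c2)[nH]c2cc(OC)ccc2c1=O` is not yet measured; it differs from compound 1 by nitro in place of isopropoxy on an aromatic carbon. Among the measured compounds shown here, no measured step bears on this change in a readable way, and the three values shown give no sign of any step in either direction. For compound 4 the expected step is a step that the limit leaves unreadable from compound 1 to compound 4. Compound 4 is estimated in this assay at 30000 nM, within 12000 nM to 100000 nM, most likely again reported only as the limit.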

Compound 4, half-maximal effective concentration: > 21500 nM
Compound 4: no number, only a limit; the forecaster's own chance of this, stated with the estimate: 80%; the middle value does not contradict the limit.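

In this assay compound 4 gives only a limit, > 21500 nM. No step from compound 1, compound 2 or compound 3 to compound 4 can be read, since all four compounds share one limit: the limit of > 21500 nM in this assay, at which 4 of the 4 values shown sit.

The compounds shown leave open whether any substituent on the pendant aromatic ring changes the half-maximal effective concentration in this assay.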